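The source may hold more compounds than are shown below. What is called first, only, known or untested is meant among the compounds shown, and "the series" means these compounds.

Measured so far:
- compound 1, `CCc1cccc(N2CCCC(=O)N2)c1`: 3000 nM
- compound 2, `O=C1CCCN(c2ccccc2Cl)N1`: 99000 nM

Both numbers come from an assay on isolated protein for inhibition of Polyunsaturated fatty acid 5-lipoxygenase (Homo sapiens); on this read-out higher numbers stand for weaker inhibition and lower numbers for stronger inhibition. Compound 1 has the lowest of the two numbers; compound 2 has the higher one, and the gap between them lies beyond the usual scatter of this assay. The two compounds differ in more than one place, so nothing is drawn from that gap about any single change.

Compound 3, `O=C1CCCN(c2cccc(CO)c2)N1`, has not yet been measured in this assay. It differs from compound 1 in one place: hydroxy in place of methyl on a saturated chain carbon bound to an aromatic carbon; seen one bond further out, an ethyl becomes a hydroxymethyl. Among the compounds with values here, no measured pair shows this change, so the expectation for compound 3 rests on compound 1 alone. The step from compound 1 to compound 3 is expected to be a 2.0-fold higher number from compound 1 to compound 3 (0.30 log units; within the scatter), a modest move toward a higher number, close to the edge of the scatter. The estimate for compound 3 in this assay is 6000 nM, with a range from 1500 nM to 25000 nM.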

Compound 3, half-maximal inhibitory concentration: 53000 nM
Estimate against measurement, compound 3: 8.8-fold (0.95 log units) below; measured number outside the range, above it.
By their numbers in this assay, from the lowest: compound 1; then compounds 3 and 2 (each within the scatter of the next).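

In this assay, turning the ethyl of compound 1 into a hydroxymethyl gives an 18-fold higher number from compound 1 to compound 3 (1.25 log units; beyond the scatter), a large loss of inhibition from a change of only 1 heavy atom. Within the data shown here, this is the first comparison here between compounds that differ in one place, and it shows that the number responds strongly to what sits on this saturated chain carbon bound to an aromatic carbon: the entering hydroxy carries 1 hydrogen-bond donor and 1 hydrogen-bond acceptor, the leaving methyl has neither, and that small exchange is enough to weaken inhibition well beyond the scatter. Nothing measured here bears on why the number rises, so the result fixes the size of the step and not its cause.

The compounds shown leave open whether the loss belongs to the hydroxy group alone or would also follow other groups at the end of this chain, such as an amine, a methyl ether or a fluorine. They also leave open whether a longer chain, such as a propyl, in place of the ethyl would bring the number lower.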